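Aryl variation on the pyrazole ring of the carboxylic acid series

The compounds below may be only part of what the source reports. "The series", "measured", "known", "first", "only" and "open" are said of these compounds alone.

Measured so far:
compound 1 `Cc1nn(-c2nc(-c3ccc(Cl)c(Cl)c3)c(SC(C)C)s2)c(C(=O)O)c1-c1cnccn1` — 14000 nM
compound 2 `Cc1nn(-c2nc(-c3ccc(Cl)c(Cl)c3)c(SC(C)C)s2)c(C(=O)O)c1-c1ccccc1C(F)(F)F` — 5200 nM

In a functional assay on BJAB cells (Homo sapiens) for antiproliferative activity, with a stated time of 4 days (a lower number here means that less compound is needed, a higher number that more compound is needed for the effect), compound 1 gives 14000 nM and compound 2 gives 5200 nM. Among the compounds with values here, the only step between them, a 2.7-fold lower number from compound 1 to compound 2 (0.43 log units; beyond the scatter), shows that the aromatic group on the five-membered ring is a place where the number moves. Compound 2 holds the lowest number of the two; compound 1 is its nearest neighbour and stands higher, beyond the scatter.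

Compound 3 `COc1cc(Cl)cc(-c2c(C)nn(-c3nc(-c4ccc(Cl)c(Cl)c4)c(SC(C)C)s3)c2C(=O)O)c1` has not yet been measured. It differs from compound 2 in one place: 3-chloro-5-methoxyphenyl in place of 2-(trifluoromethyl)phenyl on an aromatic carbon.

Within the data shown here, only the step from compound 1 to compound 2 bears on this change, and it was modest. Compound 3 keeps a six-membered carbon-only aromatic ring, as in compound 2, so a step of similar or smaller size than a 2.7-fold lower number from compound 1 to compound 2 (0.43 log units; beyond the scatter) is expected, and its direction is open. The working estimate for compound 3 in this assay is 4000 nM, with a range of 1500 nM to 12000 nM, which means an expected step of a 1.3-fold lower number from compound 2 to compound 3 (0.11 log units; within the scatter).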

Compound 3, half-maximal effective concentration: 760 nM
Compound 3: the middle estimate sits 5.3-fold (0.72 log units) above what was measured; measured number outside the range, below it.
By their numbers in this assay, from the lowest: compound 3; then compound 2; then compound 1.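

In this assay the step of a 6.8-fold lower number from compound 2 to compound 3 (0.84 log units; beyond the scatter) shows that this aromatic carbon of the five-membered ring remains sensitive even when the group keeps one six-membered aromatic ring of carbon only, so ring type alone does not set the number. The step of an 18-fold lower number from compound 1 to compound 3 (1.27 log units; beyond the scatter) widens the span seen at this position well beyond the first comparison, with 3-chloro-5-methoxyphenyl in place of pyrazin-2-yl, and compound 3 now holds the lowest number of the three, with both of its steps beyond the scatter. No measurement at hand explains this change, so the parts played by the chlorine, the methoxy group and the departure of the trifluoromethyl group stay unassigned.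

The compounds shown leave open whether the chlorine or the methoxy group alone on a phenyl ring would account for the number of compound 3, or whether both are needed. They also leave open how an amine or a morpholine on that phenyl ring, or an amide in place of the carboxy group, would compare with compound 3.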